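Trimming ethoxy to methoxy: what to expect for compound 4

The source may hold more compounds than are shown below. What is called first, only, known or untested is meant among the compounds shown, and "the series" means these compounds.

Three compounds have results in a functional assay on HCT-116 cells (Homo sapiens) for inhibition, read by sulforhodamine B assay, with a stated time of 48 h, tested at 50 uM; a higher number here means more inhibition of growth at the concentration tested, a lower number less inhibition of growth:
Compound 1 `COc1cc2c(cc1CC=C(C)C)/C(=N/NC(N)=O)C[C@@H](c1ccc(O)cc1)O2` gives 87%.
Compound 2 `CCOc1ccc([C@@H]2CC(=O)c3cc(CC=C(C)C)c(OC)cc3O2)cc1` gives 65%.
Compound 3 `COc1ccc([C@@H]2C/C(=N/OCc3cn(-c4ccc(O)cc4)nn3)c3cc(CC=C(C)C)c(OC)cc3O2)cc1` gives 65%.

On these numbers compound 2 stands level with compound 3 at the digits reported, the two together the lowest of the three; compound 1 lies higher by an amount beyond the usual scatter. Compound 4 `COc1ccc([C@@H]2CC(=O)c3cc(CC=C(C)C)c(OC)cc3O2)cc1` has not yet been measured. It differs from compound 2 in one place: hydrogen in place of methyl on a saturated chain carbon bound to an oxygen on an aromatic ring. Among the compounds with values here, no pair of measured compounds differs in only one place, so nothing here shows what such a change does to growth inhibition in this assay. The change from ethoxy to methoxy is expected to move the result little, in no direction beyond the scatter; the expected step is a number 3 percentage points lower from compound 2 to compound 4 (within the scatter). Compound 4 is therefore estimated at about 62%, between 45% and 78%.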

Compound 4, percent growth inhibition at one concentration: 68%
Compound 4: middle estimate off by 6 percentage points, on the low side; low and high end bracket the measured number.
By their numbers in this assay, from the lowest: compounds 2, 3 and 4 (each within the scatter of the next); then compound 1.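

In this assay, within the data shown here, the exchange of 4-ethoxyphenyl for 4-methoxyphenyl gives a number 3 percentage points higher from compound 2 to compound 4 (within the scatter) and is the first single change that can be read. At this position, on a saturated chain carbon bound to an oxygen on an aromatic ring, methyl and hydrogen therefore give growth inhibition that stands within the scatter. No measurement at hand bears on the reason for this result. The compounds shown leave open how a longer chain such as propoxy, or an amine on the same ring, would read in this assay.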